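Moving the Chlorine Around the Benzyl Sulfanyl Group

The source may hold more compounds than are shown below. What is called first, only, known or untested is meant among the compounds shown, and "the series" means these compounds.

Compound 3 `C/C(C#Cc1ccccc1)=N\N/C(N)=N/S(=O)(=O)c1cc(C)c(Cl)cc1SCc1ccccc1Cl` gives 129000 nM in a functional assay on HCT-116 cells (Homo sapiens) for antiproliferative activity, read by MTT assay, with a stated time of 72 h (on this read-out higher numbers stand for weaker inhibition and lower numbers for stronger inhibition), the lowest of the three numbers, though its steps to compound 1 `C/C(C#Cc1ccccc1)=N\N/C(N)=N/S(=O)(=O)c1cc(C)c(Cl)cc1SCc1cccc(C)c1` with 160000 nM and to compound 2 `C/C(C#Cc1ccccc1)=N\N/C(N)=N/S(=O)(=O)c1cc(C)c(Cl)cc1SCc1ccc(C(F)(F)F)cc1` with 160000 nM both lie within the scatter. Compound 4 `C/C(C#Cc1ccccc1)=N\N/C(N)=N/S(=O)(=O)c1cc(C)c(Cl)cc1SCc1ccc(Cl)cc1` differs from compound 3 by 4-chlorophenyl in place of 2-chlorophenyl on a saturated chain carbon bound to a sulfur. Among the compounds with values here, the steps that bear on this change are those that exchange the aryl group on the same carbon: a 1.2-fold lower number from compound 1 to compound 3 (0.09 log units; within the scatter) and a 1.2-fold lower number from compound 2 to compound 3 (0.09 log units; within the scatter), while no change at the digits printed from compound 1 to compound 2 (within the scatter) also stayed flat. Three different aryl groups at this position thus gave no movement in this assay beyond the scatter, so compound 4 is expected to remain at the same level, with a 1.1-fold higher number from compound 3 to compound 4 (0.04 log units; within the scatter). Compound 4 is estimated at 140000 nM, within 70000 nM to 280000 nM.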

Compound 4, half-maximal inhibitory concentration: 10000 nM
Compound 4: middle estimate off by 14-fold (1.15 log units), on the high side; measured number outside the range, below it.
By their numbers in this assay, from the lowest: compound 4; then compounds 3, 1 and 2 (each within the scatter of the next).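

On the saturated chain carbon bound to a sulfur, the aryl group does matter in this assay: the same atoms, joined differently as 4-chlorophenyl in place of 2-chlorophenyl, give a large drop (a 13-fold lower number from compound 3 to compound 4 (1.11 log units; beyond the scatter)). The 4-chlorophenyl group also separates compound 4 from the two other aryl groups (a 16-fold lower number from compound 2 to compound 4 (1.20 log units; beyond the scatter); a 16-fold lower number from compound 1 to compound 4 (1.20 log units; beyond the scatter)), so the flat picture held only among compound 1, compound 2 and compound 3. Nothing given here accounts for this drop. As far as these compounds go, whether bromo, methoxy or an amine in place of that chloro would keep the lower number remains open, as does the effect of a longer chain in place of the saturated carbon.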